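The source may report more compounds than this note shows. Statements on the series, on what has been measured and on what is new or still open speak of the compounds shown alone.

Measured compounds in this study:
compound 1 `CC1=C(N2CC2)C(=O)C(CC(C)OC(N)=O)=C(N2CC2)C1=O` with 5.86
compound 2 `CCCC1=C(N2CC2)C(=O)C(CCC)=C(N2CC2)C1=O` with 4.32
compound 3 `CCCC1=C(N2CC2)C(=O)C(CCOC(N)=O)=C(N2CC2)C1=O` with 4.9

In a functional assay on L1210 cells (Mus musculus), with a stated time of 1 days (a lower number here means a less potent compound, a higher number a more potent compound, by a factor of ten per unit of this negative logarithm), compound 1 stands highest of the three numbers measured. Its nearest neighbour is compound 3, and compound 2 lies furthest away; both gaps are beyond the scatter, so compound 1 is the most potent compound in this set.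

The unmeasured compound 4 `CC1=C(N2CC2)C(=O)C(CCCOC(N)=O)=C(N2CC2)C1=O` differs from compound 1 in this way: a group of 6 heavy atoms (3 carbon, 1 nitrogen, 2 oxygen; no ring) in place of a group of 6 heavy atoms (3 carbon, 1 nitrogen, 2 oxygen; no ring), on a saturated chain carbon bound to a double-bonded ring carbon The two compounds are built from the same atoms, joined differently; in compound 4 the group that enters is 2-(carbamoyloxy)ethyl, standing on a saturated chain carbon bound to a double-bonded ring carbon.

For the measured compounds named here, only one measured step bears on this change, and only loosely: a number 0.58 log units higher from compound 2 to compound 3 (beyond the scatter) That step shows what a carbamate on the chain is worth against a plain chain. In the step from compound 1 to compound 4, however, a carbamate is present on both sides, so the measured step gives no direct guide to the size of the change, and the shared core stays the same.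

Going by the values given here, with no step that speaks directly to this rearrangement, the expectation for compound 4 in this assay is a number close to that of compound 1, with a small step of a number 0.16 log units lower from compound 1 to compound 4 (within the scatter) that is expected to lie within the scatter. Compound 4 is therefore estimated at 5.7, within a range from 5.1 to 6.3.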

Compound 4, logarithm of the reciprocal of the active concentration, log(1/C): 5.55
Compound 4: the middle estimate sits 0.15 log units above what was measured, within the range that was stated.
By their numbers in this assay, from the lowest: compound 2; then compound 3; then compound 4; then compound 1.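

The earlier compounds shown here showed only what a carbamate on the chain is worth against a plain chain, as in the step of a number 0.58 log units higher from compound 2 to compound 3 (beyond the scatter) in this assay. The new pair goes further: the carbamate is present on both sides and the atoms are the same, so only the way they are joined differs, and that alone gives a step of a number 0.31 log units lower from compound 1 to compound 4 (beyond the scatter) in this assay. This step is modest but beyond the scatter, so at this place on a saturated chain carbon bound to a double-bonded ring carbon, the arrangement of the group counts as well as its presence, and 2-(carbamoyloxy)ethyl does not fully match the group of compound 1.

Nothing measured here explains why the two arrangements differ. The compounds shown also leave open whether a longer chain carrying the carbamate would continue this trend, and whether an amine or a carboxylic acid could stand in place of the carbamate at this position without a loss in this assay.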